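Bromine analogue in the chromone ester series

The source may report more compounds than this note shows. Statements on the series, on what has been measured and on what is new or still open speak of the compounds shown alone.

For the measured compounds named here, compound 3 `COC(=O)c1cc(C)ccc1OC(=O)COc1cc(O)c2c(=O)cc(-c3ccccc3)oc2c1` gives 25700 nM in a functional assay on cells (T-cell, Mus musculus, strain BALB/c) for inhibition, read by MTT assay, with a stated time of 72 h (on this read-out lower numbers stand for stronger inhibition and higher numbers for weaker inhibition), the second highest of the three numbers so far: its nearest neighbour is compound 2 `COC(=O)c1cccc(C)c1OC(=O)COc1cc(O)c2c(=O)cc(-c3ccccc3)oc2c1` with 39100 nM, within the scatter, while compound 1 `COC(=O)c1ccc(Cl)cc1OC(=O)COc1cc(O)c2c(=O)cc(-c3ccccc3)oc2c1` with 12400 nM lies further off. Compound 4 `COC(=O)c1ccc(Br)cc1OC(=O)COc1cc(O)c2c(=O)cc(-c3ccccc3)oc2c1` differs from compound 3 by a group of 11 heavy atoms (8 carbon, 2 oxygen, 1 bromine; one six-membered aromatic ring of carbon only) in place of a group of 11 heavy atoms (9 carbon, 2 oxygen; one six-membered aromatic ring of carbon only), on an oxygen next to a carbonyl group. The relevant measured steps are a 2.1-fold higher number from compound 1 to compound 3 (0.32 log units; beyond the scatter) and a 3.2-fold higher number from compound 1 to compound 2 (0.50 log units; beyond the scatter), both showing higher numbers when the chlorine-bearing group of compound 1 is exchanged for a carbon-only group. Since compound 4 carries bromine where compound 1 carries chlorine, a lower number is expected, roughly reversing that step, giving an expected 2.0-fold lower number from compound 3 to compound 4 (0.30 log units; within the scatter). The estimated value for compound 4 is 13000 nM, with a range of 6000 nM to 30000 nM.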

Compound 4, half-maximal inhibitory concentration: 17600 nM
Compound 4: middle estimate off by 1.4-fold (0.13 log units), on the low side; the measured number falls inside the stated range.
By their numbers in this assay, from the lowest: compounds 1, 4, 3 and 2 (each within the scatter of the next, the first and the last beyond it).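

In this assay, bromo in place of chloro on an aromatic carbon is the only exchange of one halogen for another shown, and a 1.4-fold higher number from compound 1 to compound 4 (0.15 log units; within the scatter) leaves the two halogens not told apart. Against the carbon-only groups, the bromine-bearing group separates from only one: a 2.2-fold lower number from compound 2 to compound 4 (0.35 log units; beyond the scatter) lies beyond the scatter, whereas a 1.5-fold lower number from compound 3 to compound 4 (0.16 log units; within the scatter) stays within it. A halogen here is therefore not clearly set apart from every carbon-only group.

No evidence bearing on the cause of these numbers is at hand. Open, as far as these compounds go, is where an amine or a carboxylic acid in place of the bromo would stand.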